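This account rests on a few compounds, and the source may have more. Where it says the series, first, only, none or still open, it means among the compounds named here.

Compound 1 `CC(C)[C@@H](NC(=O)OC(C)(C)C)C(=O)Nc1ccc2ncnc(Nc3cccc(Br)c3)c2c1` is a bromo compound tested in a functional assay on HepG2 cells (Homo sapiens) for antiproliferative activity, read by sulforhodamine B assay, with a stated time of 72 h; on this read-out higher numbers stand for weaker inhibition and lower numbers for stronger inhibition. In that test compound 1 gives > 50000 nM, which is a limit of the assay and not a number. Compound 2 `C[C@@H](NC(=O)OC(C)(C)C)C(=O)Nc1ccc2ncnc(Nc3cccc(C(F)(F)F)c3)c2c1` gives > 50000 nM, which is also a limit. Compound 1 therefore stands with its neighbour at the limit of > 50000 nM in this assay, at which 2 of the 3 values shown sit. Only compound 3 `CC(C)[C@@H](NC(=O)OC(C)(C)C)C(=O)Nc1ccc2ncnc(Nc3cccc(C(F)(F)F)c3)c2c1` gives a number, 4300 nM.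

Two measured steps lead to compound 3, and both start from a limit. Trifluoromethyl in place of bromo on an aromatic carbon gives an at least 11-fold lower number from compound 1 to compound 3 (1.06 log units; beyond the scatter). Isopropyl in place of methyl on the chain carbon gives an at least 11-fold lower number from compound 2 to compound 3 (1.06 log units; beyond the scatter).

Compound 4 `CC(C)C[C@@H](NC(=O)OC(C)(C)C)C(=O)Nc1ccc2ncnc(Nc3cccc(Br)c3)c2c1` keeps the bromo group and the shared core of compound 1, and only the chain group changes: isobutyl in place of isopropyl on a saturated chain carbon bound to an amide-type nitrogen and a carbonyl carbon. The second step above is the one measured at this place, and it is large, but it was seen with trifluoromethyl on the aromatic carbon. With bromo there, compound 1 has not left the limit, even with isopropyl. A slightly lower number is therefore the most that can be expected, with nothing beyond the scatter. The expected change is an at least 1.4-fold lower number from compound 1 to compound 4 (0.15 log units; that floor lies within the scatter). For compound 4 the estimated value in this assay is 35000 nM, with an expected range of 12000 nM to 80000 nM.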

Compound 4, half-maximal inhibitory concentration: 25000 nM
Compound 4: middle estimate off by 1.4-fold (0.15 log units), on the high side, and the stated range covers the measured number.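

For the compounds shown here, until now, the only number rather than a limit in this assay had come with trifluoromethyl on the aromatic carbon, in compound 3. Compound 4 now gives a number with bromo kept there, so a change in the chain group alone is enough to bring a bromo compound off the limit, with isobutyl in place of isopropyl giving an at least 2.0-fold lower number from compound 1 to compound 4 (0.30 log units; that floor lies within the scatter). The true size of this step stays unknown and may be larger than that floor, because compound 1 has only a limit of the assay and not a number: the limit of > 50000 nM in this assay, at which 2 of the 4 values shown sit.

As far as these compounds go, compound 3 and compound 4 differ in two places, so they cannot be compared directly, and it remains open what isobutyl would do with trifluoromethyl on the aromatic carbon. From the compounds shown here alone, it is also open how this saturated chain carbon would respond to a longer chain, a benzyl group, or a chain ending in an amine or a carboxylic acid, and whether any of these would move the number beyond the scatter.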